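This account rests on a few compounds, and the source may have more. Where it says the series, first, only, none or still open, it means among the compounds named here.

Compound 3 `CC#CC(CC(=O)O)c1ccc(OCc2ccc(C(=O)N3CCN(c4ccc([N+](=O)[O-])cc4)CC3)s2)cc1` carries a 4-nitrophenyl on the ring amine and gives 231 nM in a functional assay on HEK293 cells for agonist activity at Free fatty acid receptor 1 (Homo sapiens), read by fluorescence and calcium flux; a higher number here means that more compound is needed for the effect, a lower number that less compound is needed. Compound 2 `CC#CC(CC(=O)O)c1ccc(OCc2ccc(C(=O)N3CCN(c4ccc(OC)cc4)CC3)s2)cc1`, with 4-methoxyphenyl in that place, gives 289 nM in this assay, and the two lie within the scatter, a 1.3-fold lower number from compound 2 to compound 3 (0.10 log units; within the scatter). Compound 1 `CC#CC(CC(=O)O)c1ccc(OCc2ccc(C(=O)N3CCN(C)CC3)s2)cc1`, with methyl on that nitrogen, reaches only the limit > 5000 nM in this assay (the limit of > 5000 nM in this assay, at which 1 of the 3 values shown sits). Of the two numbers shown, the one for compound 3 is the lower, though the gap to compound 2 is within the scatter. Compound 4 `CC#CC(CC(=O)O)c1ccc(OCc2ccc(C(=O)N3CCN(c4ccc(Cl)cc4)CC3)s2)cc1` differs from compound 3 by chloro in place of nitro on an aromatic carbon. Among the compounds with values here, the one step that bears on this, a 1.3-fold lower number from compound 2 to compound 3 (0.10 log units; within the scatter), exchanged the group on that aromatic carbon and stayed within the scatter; the large steps of an at least 17-fold lower number from compound 1 to compound 2 (1.23 log units; beyond the scatter) and an at least 21-fold lower number from compound 1 to compound 3 (1.33 log units; beyond the scatter) concern the whole aryl group, which compound 4 keeps. The expected step is therefore small, a 1.1-fold higher number from compound 3 to compound 4 (0.03 log units; within the scatter). Compound 4 is estimated at 250 nM, between 110 nM and 600 nM.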

Compound 4, half-maximal effective concentration: 133 nM
Compound 4: the middle estimate sits 1.9-fold (0.27 log units) above what was measured, and the stated range covers the measured number.
By their numbers in this assay, from the lowest: compounds 4, 3 and 2 (each within the scatter of the next, the first and the last beyond it). At a limit, above all of these: compound 1.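

Chloro in place of nitro gives a 1.7-fold lower number from compound 3 to compound 4 (0.24 log units; within the scatter), so this exchange does not separate the two compounds. Chloro in place of methoxy gives a 2.2-fold lower number from compound 2 to compound 4 (0.34 log units; beyond the scatter), the first change at this position to pass the scatter, though only modestly. Replacing the methyl on the ring nitrogen with 4-chlorophenyl gives an at least 37-fold lower number from compound 1 to compound 4 (1.57 log units; beyond the scatter), a step that rests on a limit rather than a number: the limit of > 5000 nM in this assay, at which 1 of the 4 values shown sits.

As far as these compounds go, it remains open how an amine or a carboxylic acid would fare at this position. Also open, from the compounds shown here alone, is whether chloro elsewhere on the six-membered ring would give a similar number.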